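The compounds below may be only part of what the source reports. "The series", "measured", "known", "first", "only" and "open" are said of these compounds alone.

Compound 1 `CN1C(=O)N(c2ccccc2)C2NC(=S)N(/N=C/C=C/c3ccccc3)C21` and compound 2 `CCN1C(=O)N(c2ccccc2)C2NC(=S)N(/N=C/C=C/c3ccccc3)C21` share one core and differ only by methyl in place of hydrogen on a saturated chain carbon bound to an amide-type nitrogen in a ring. In an ADME assay on HEK293 cells (Homo sapiens) for inhibition, read by MTT assay, with a stated time of 72 h (on this read-out lower numbers stand for stronger inhibition and higher numbers for weaker inhibition), compound 1 gives 167000 nM, while compound 2 gives 2170 nM, so this single change brought a 77-fold lower number from compound 1 to compound 2 (1.89 log units; beyond the scatter). Compound 3 `CCN1C(=O)N(CC)C2C1N=C(SC)N2/N=C/C=C/c1ccccc1[N+](=O)[O-]` is built on another core; the difference between the two cores is not broken down here. In this assay compound 3 stands as "not determined" (no result reported), so no number exists for it. Compound 4 `CCSC1=NC2C(N(CC)C(=O)N2CC)N1/N=C/C=C/c1ccccc1[N+](=O)[O-]` differs from compound 3 by methyl in place of hydrogen on a saturated chain carbon bound to a sulfur, the same kind of change as from compound 1 to compound 2, although here the carbon is bound to a sulfur rather than to an amide-type nitrogen in a ring. With no number for compound 3, the earlier step cannot simply be carried over. For the measured compounds named here, the only measured anchors are compound 2 at 2170 nM and the step of a 77-fold lower number from compound 1 to compound 2 (1.89 log units; beyond the scatter). Compound 4 is therefore expected to give roughly 5000 nM in this assay, estimated to fall between 500 nM and 50000 nM.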

Compound 4, half-maximal inhibitory concentration: 221000 nM
For compound 4 the middle estimate is 44-fold (1.65 log units) below the measured one; measured number above the stated range.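

No step can be read from compound 3 to compound 4 in this assay. The compounds shown leave open what the change from methylsulfanyl to ethylsulfanyl does to this number. Nothing shown here offers an explanation for the result of compound 4.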